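Acyl variation on the cyclic amine: cytotoxicity working notes

This account rests on a few compounds, and the source may have more. Where it says the series, first, only, none or still open, it means among the compounds named here.

Measured so far in a functional assay on HEL cells (Homo sapiens) for cytotoxicity, read by microscopy; on this read-out lower numbers stand for higher toxicity in this test and higher numbers for lower toxicity in this test:
compound 1 `Cc1cn([C@@H]2O[C@H](CO[Si](C)(C)C(C)(C)C)[C@@]3(OS(=O)(=O)C=C3NCC(N)=O)[C@H]2O[Si](C)(C)C(C)(C)C)c(=O)n(C)c1=O`, with the value 16000 nM;
compound 3 `Cc1cn([C@@H]2O[C@H](CO[Si](C)(C)C(C)(C)C)[C@@]3(OS(=O)(=O)C=C3NC(N)=O)[C@H]2O[Si](C)(C)C(C)(C)C)c(=O)n(C)c1=O`, with the value 16000 nM;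
compound 2 `CC(=O)NC1=CS(=O)(=O)O[C@@]12[C@@H](CO[Si](C)(C)C(C)(C)C)O[C@@H](n1cc(C)c(=O)n(C)c1=O)[C@@H]2O[Si](C)(C)C(C)(C)C`, whose result is a limit of the assay, >= 80000 nM.

Compound 3 sits level with compound 1, the two differing by no change at the digits printed from compound 1 to compound 3 (within the scatter). Against compound 2 the picture is different: an at least 5.0-fold lower number from compound 2 to compound 3 (0.69 log units; beyond the scatter), the only step in the set that goes beyond the scatter, and it rests on a limit, (the limit of >= 80000 nM in this assay, at which 1 of the 3 values shown sits).

The next compound, compound 4 `COC(=O)NC1=CS(=O)(=O)O[C@@]12[C@@H](CO[Si](C)(C)C(C)(C)C)O[C@@H](n1cc(C)c(=O)n(C)c1=O)[C@@H]2O[Si](C)(C)C(C)(C)C`, is not yet measured. It differs from compound 3 as follows: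
methoxy in place of amino on a carbonyl carbon

Going by the values given here, the step that bears on this change is the one between compound 2 and compound 3, since both it and the present change sit on the same carbonyl carbon. Removing the amino there and putting a methyl in its place moved the number up to the limit; putting a methoxy in its place is expected to move it in the same direction, though perhaps not as far. In this assay compound 4 is therefore expected to give 40000 nM, within 16000 nM to 100000 nM, which is expected to mean a 2.5-fold higher number from compound 3 to compound 4 (0.40 log units; beyond the scatter).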

Compound 4, minimum cytotoxic concentration: >= 50000 nM
Compound 4: a limit, no number; the forecaster's own chance of this, stated with the estimate: 40%; at least 1.2-fold (0.09 log units) between middle value and limit.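

Replacing amino with methoxy on the carbonyl carbon gives, in this assay, an at least 3.1-fold higher number from compound 3 to compound 4 (0.49 log units; beyond the scatter), so methoxy joins methyl as a second replacement for the amino that raises the number beyond the scatter. The comparison with the carbamoylmethyl group points the same way, with an at least 3.1-fold higher number from compound 1 to compound 4 (0.49 log units; beyond the scatter); among the four compounds, the two with numerical values, compound 1 and compound 3, sit level, while the other two, compound 2 and compound 4, both end at limits of the assay. The step between compound 2 and compound 4 cannot be read, so methoxy and methyl cannot be ordered on this carbonyl carbon, and the result for compound 4 is itself only a limit: the limit of >= 50000 nM in this assay, at which 1 of the 4 values shown sits.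

On these data alone, how far the number rises with methyl or methoxy remains open, as neither limit gives an endpoint. Also open, as far as these compounds go, is whether the higher numbers follow from the loss of the amino as such, a question that a methylamino or dimethylamino group, or an ethoxy group or longer alkoxy chain, on the same carbonyl carbon would bear on.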